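This account rests on a few compounds, and the source may have more. Where it says the series, first, only, none or still open, it means among the compounds named here.

Measured so far in a physicochemical assay for lipophilicity; a higher number here means a more lipophilic compound, a lower number a more polar compound:

- Compound 1 `COc1ccc(C2=[N+]3C(=Nc4c(-c5ccccc5)c5c(n4[B-]3(F)F)-c3ccc(OCC(=O)N[C@@H](CC(=O)O)C(=O)O)cc3CC5)C(c3ccccc3)=C2I)cc1`: -0.77
- Compound 2 `COc1ccc2c(c1)CCc1c(-c3ccccc3)c3n(c1-2)[B-](F)(F)[N+]1=C(c2ccc(OCC(=O)O)cc2)C(I)=C(c2ccccc2)C1=N3`: 0.92
- Compound 3 `COc1ccc2c(c1)CCc1c(-c3ccccc3)c3n(c1-2)[B-](F)(F)[N+]1=C(c2ccc(OCC(=O)N[C@@H](CC(=O)O)C(=O)O)cc2)C(I)=C(c2ccccc2)C1=N3`: -0.73

Compound 3, at -0.73, lies within the usual scatter of compound 1 and far under compound 2. The next compound to consider is compound 4 `COc1ccc2c(c1)CCc1c(-c3ccccc3)c3n(c1-2)[B-](F)(F)[N+]1=C(c2ccc(OCC(=O)N[C@@H](CCC(=O)O)C(=O)O)cc2)C(I)=C(c2ccccc2)C1=N3`. It differs from compound 3 in one place, with carboxymethyl in place of carboxy on a saturated chain carbon, two bonds along the chain from an amide-type nitrogen and a carbonyl carbon. The same difference can be read as (1,2-dicarboxyethyl)amino becoming (1,3-dicarboxypropyl)amino.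

Among the measured compounds shown here, only one measured step bears on this, and only indirectly. That step, a number 1.65 log units lower from compound 2 to compound 3 (beyond the scatter), is large and beyond the scatter, but it swaps a hydroxy for the whole (1,2-dicarboxyethyl)amino group. For the measured compounds named here, the change to compound 4 keeps that group and only extends it, and no measured pair shows this change alone. A much smaller step is therefore expected in this assay, probably upward and not beyond the scatter. The estimated step is a number 0.08 log units higher from compound 3 to compound 4 (within the scatter). Compound 4 is expected at -0.65, with an estimated range from -1.05 to -0.3.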

Compound 4, partition coefficient: -0.71
Estimate against measurement, compound 4: 0.06 log units above; measured number inside the range.
By their numbers in this assay, from the lowest: compounds 1, 3 and 4 (each within the scatter of the next); then compound 2.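

In this assay, carboxymethyl in place of carboxy on this saturated chain carbon gives a number 0.02 log units higher from compound 3 to compound 4 (within the scatter), so at this position the two chain lengths cannot be told apart in this measurement. Read from the hydroxy compound, (1,3-dicarboxypropyl)amino on the carbonyl carbon gives a number 1.63 log units lower from compound 2 to compound 4 (beyond the scatter), a large step like a number 1.65 log units lower from compound 2 to compound 3 (beyond the scatter) for the (1,2-dicarboxyethyl)amino group, so among compounds 2, 3 and 4 the large difference comes with replacing the hydroxy, whichever of these two groups enters. Nothing shown here gives a cause for either large step or for the absence of a clear difference between the two chains.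

Still open, on these data alone, is whether a longer chain than the 2-carboxyethyl now present, or an amine in place of the carboxylic acid at the end of that chain, would also leave the number where it stands. As far as these compounds go, it is also open whether carboxymethyl in place of carboxy would give a similarly small step on compound 1, where the same (1,2-dicarboxyethyl)amino group sits elsewhere on the shared core.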